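Solubility notes: a second swap of the aromatic substituent

This account rests on a few compounds, and the source may have more. Where it says the series, first, only, none or still open, it means among the compounds named here.

For the measured compounds named here, compound 2, `CC(C)n1cc(-c2ccnc3[nH]c(C4CCN(CC(=O)N(C)C)CC4)cc23)cnc1=O`, is the only compound in the set with a number in a physicochemical assay for solubility, in phosphate buffer, at pH 7.4; on this read-out lower numbers stand for lower solubility and higher numbers for higher solubility; in this assay compound 2 gives 910000 nM. Compound 1, `CN(C)C(=O)CN1CCC(c2cc3c(-c4ccc(=O)n(C)c4)ccnc3[nH]2)CC1`, gives > 1000000 nM in this assay, which is a limit of the assay and not a number. That limit is recorded as the limit of > 1000000 nM in this assay, at which 1 of the 2 values shown sits. Going by the values given here, the measured step of an at least 1.0-fold lower number from compound 1 to compound 2 (0.04 log units; that floor lies within the scatter) therefore says only that the two compounds are not separated beyond the scatter.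

Compound 3, `COc1cc(=O)n(C)cc1-c1ccnc2[nH]c(C3CCN(CC(=O)N(C)C)CC3)cc12`, differs from compound 2 by a group of 10 heavy atoms (7 carbon, 1 nitrogen, 2 oxygen; one six-membered aromatic ring with 1 hetero atom) in place of a group of 10 heavy atoms (7 carbon, 2 nitrogen, 1 oxygen; one six-membered aromatic ring with 2 hetero atoms), on an aromatic carbon. Among the compounds with values here, the one measured step that bears on this change is the earlier swap at the same aromatic carbon, an at least 1.0-fold lower number from compound 1 to compound 2 (0.04 log units; that floor lies within the scatter), which lay within the scatter; no measured step covers the entering group itself. No step beyond the scatter is expected in this assay, in either direction. Compound 3 is therefore estimated at 900000 nM, with a range from 400000 nM to 1500000 nM. The expected step is a 1.0-fold lower number from compound 2 to compound 3 (0.00 log units; within the scatter).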

Compound 3, solubility: 670000 nM
Compound 3: middle estimate off by 1.3-fold (0.13 log units), on the high side; low and high end bracket the measured number.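

In this assay the second swap at this aromatic carbon again stays within the scatter, a 1.4-fold lower number from compound 2 to compound 3 (0.13 log units; within the scatter), so these two ring groups, equal in heavy atom count, are not separated here. Compounds 1 and 3 add a comparison the earlier pair did not offer, methoxy in place of hydrogen on an aromatic carbon of the same ring group, read as an at least 1.4-fold lower number from compound 1 to compound 3 (0.17 log units; that floor lies within the scatter). That step gives only a floor within the scatter, and the entry for compound 1 is a limit of the assay and not a number: the limit of > 1000000 nM in this assay, at which 1 of the 3 values shown sits.

As far as these compounds go, whether an amine or a carboxylic acid in place of methoxy on this ring would give a step beyond the scatter stays open. So does the effect of a longer chain in place of the isopropyl group of compound 2.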